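The source may hold more compounds than are shown below. What is called first, only, known or untested is meant among the compounds shown, and "the series" means these compounds.

Measured compounds:
Compound 1 `O=C(O)CSC(CC(=O)c1ccccc1)C(=O)O`, which in a functional assay on HeLa cells (Homo sapiens) (a lower number here means a stronger inhibitor, a higher number a weaker inhibitor), gives 15000 nM.
Compound 2 `Cc1ccc(C(=O)CC(SCC(=O)O)C(=O)O)cc1C`, which in this assay gives 3810 nM.
Compound 3 `Cc1ccc(C(=O)CC(SCC(=O)O)C(=O)O)c(C)c1`, which in this assay gives 3830 nM.

Among these three, compound 1 stands at the highest number: it is the weakest inhibitor of the set, and both compound 2 and compound 3, each bearing two methyl groups on the aromatic ring, give lower numbers that lie beyond the usual scatter. Compound 2 and compound 3 themselves sit within the scatter of each other, so nothing separates them.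

Compound 4 `CC(C)c1ccc(C(=O)CC(SCC(=O)O)C(=O)O)cc1` has not yet been measured. Compared with compound 1, the change is isopropyl in place of hydrogen on an aromatic carbon. Since every substituted ring seen so far gives a lower number than the bare ring of compound 1, a single isopropyl group on an aromatic carbon is expected to move the number in the same direction, by a step somewhat beyond the scatter. The expected step is a 3.3-fold lower number from compound 1 to compound 4 (0.52 log units; beyond the scatter). Compound 4 is thus estimated to give 4500 nM in this assay, with a likely range from 1500 nM to 13000 nM.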

Compound 4, half-maximal inhibitory concentration: 3330 nM
Estimate against measurement, compound 4: 1.4-fold (0.13 log units) above, and the stated range covers the measured number.
By their numbers in this assay, from the lowest: compounds 4, 2 and 3 (each within the scatter of the next); then compound 1.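

In this assay, among these compounds, isopropyl in place of hydrogen on an aromatic carbon, para to a large group, gives a 4.5-fold lower number from compound 1 to compound 4 (0.65 log units; beyond the scatter), the first step in this set that rests on a change in one place alone. The earlier substituted compounds each carry two methyl groups on the ring, so they could not tie a lower number to any single position; here, one position and one group of 3 heavy atoms, with no ring and no hydrogen-bond donors or acceptors, are enough to give a step beyond the scatter. Nothing measured here explains why this change lowers the number.

The compounds shown leave open whether a single methyl group, a tert-butyl group or a chlorine atom at this same place would give a similar step, and whether a hydroxyl group or an amine would do so as well. They also leave open how isopropyl would compare on any other carbon of the ring, and whether the step would hold with the rest of the core changed.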